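A few compounds are considered here, and "the series" means these few. Any claim that something is new, unique, unknown or untested is made for them only; others in the source may bear on it.

Compound 1 `Cc1ccc(NC(=O)C(=O)NC(c2nc(C)c(CCO)s2)C2CCCCN2)c(F)c1`: in an ADME assay on TZM-b1 cells (Homo sapiens) for cytotoxicity, read by XTT assay, with a stated time of 3 days (on this read-out lower numbers stand for higher toxicity in this test and higher numbers for lower toxicity in this test), compound 1 gives only a limit, > 78800 nM.
Compound 2 `Cc1ccc(NC(=O)C(=O)NC(c2nc(C)c(CO)s2)C2CCCCN2)c(F)c1`: in this assay compound 2 gives only a limit, > 88000 nM.
Compound 3 `Cc1nc(C(NC(=O)C(=O)Nc2ccc(F)cc2F)C2CCCCN2)sc1CO`: in this assay compound 3 gives only a limit, > 87000 nM.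

Within the data shown here, compound 1 thus stands at a limit of this assay, and no measured compound offers a number to rank it against. The step that the two limits leave unreadable from compound 1 to compound 2 and the step that the two limits leave unreadable from compound 2 to compound 3 are both unreadable, as the limit of > 78800 nM in this assay, at which 1 of the 3 values shown sits, the limit of > 87000 nM in this assay, at which 1 of the 3 values shown sits, and the limit of > 88000 nM in this assay, at which 1 of the 3 values shown sits, show. Compound 4 `Cc1nc(C(NC(=O)C(=O)Nc2ccc(F)cc2)C2CCCCN2)sc1CCO` differs from compound 1 by 4-fluorophenyl in place of 2-fluoro-4-methylphenyl on an amide-type nitrogen. Among the measured compounds shown here, no measured step bears readably on this change. Compound 4 is therefore expected to give 90000 nM, between 40000 nM and 200000 nM, most probably again only a limit. The step that the limit leaves unreadable from compound 1 to compound 4 is expected to stay within the scatter.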

Compound 4, half-maximal cytotoxic concentration: > 88000 nM
Compound 4: a limit, no number (the forecaster's own chance of this, stated with the estimate: 85%); the middle value does not contradict the limit.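

Compound 1 and compound 4 both give only a limit in this assay, so no step can be read between them. The compounds shown leave open at what concentration any of them becomes toxic to these cells, and whether 4-fluorophenyl in place of 2-fluoro-4-methylphenyl alters that concentration.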